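This account rests on a few compounds, and the source may have more. Where it says the series, first, only, none or still open, it means among the compounds named here.

Compound 1 `N#CCC(=O)N/N=C1\C(=O)Nc2ccc(S(=O)(=O)N3CCOCC3)cc21` carries the shared core and, on a double-bonded nitrogen, a ((cyanomethyl)carbonyl)amino group. In an ADME assay on WI-38 cells (Homo sapiens) for cytotoxicity, read by sulforhodamine B assay, with a stated time of 24 h (on this read-out higher numbers stand for weaker inhibition and lower numbers for stronger inhibition), compound 1 gives 302000 nM, the second highest of three numbers, all of which sit within the scatter of one another. Compound 2 `O=C1Nc2ccc(S(=O)(=O)N3CCOCC3)cc2/C1=N/c1cccc(C(F)(F)F)c1` gives 226000 nM and compound 3 `CC(=O)N/N=C1\C(=O)Nc2ccc(S(=O)(=O)N3CCOCC3)cc21` gives 325000 nM; the steps of a 1.3-fold lower number from compound 1 to compound 2 (0.13 log units; within the scatter), a 1.1-fold higher number from compound 1 to compound 3 (0.03 log units; within the scatter) and a 1.4-fold higher number from compound 2 to compound 3 (0.16 log units; within the scatter) all stay within the scatter. Compound 4 `O=C1Nc2ccc(S(=O)(=O)N3CCOCC3)cc2/C1=N/NS(=O)(=O)c1ccccc1` differs from compound 1 by phenylsulfonyl in place of (cyanomethyl)carbonyl on an amine nitrogen. Both measured exchanges on this double-bonded nitrogen, to 3-(trifluoromethyl)phenyl and to acetamido, gave steps within the scatter, so no step beyond the scatter is expected here either. Compound 4 is therefore estimated at 290000 nM, between 140000 nM and 600000 nM, an expected step of a 1.0-fold lower number from compound 1 to compound 4 (0.02 log units; within the scatter).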

Compound 4, half-maximal inhibitory concentration: 302000 nM
Estimate against measurement, compound 4: 1.0-fold (0.02 log units) below; the range from low to high includes it.
By their numbers in this assay, from the lowest: compounds 2, 1, 4 and 3 (each within the scatter of the next).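

Exchanging the (cyanomethyl)carbonyl for phenylsulfonyl on the amine nitrogen adds an aromatic ring and raises the group to 9 heavy atoms, yet this assay shows no change at the digits printed from compound 1 to compound 4 (within the scatter). The comparisons with the other two compounds agree, with a 1.1-fold lower number from compound 3 to compound 4 (0.03 log units; within the scatter) and a 1.3-fold higher number from compound 2 to compound 4 (0.13 log units; within the scatter), so even this larger aromatic sulfonyl group gives no step beyond the scatter. Nothing available explains this lack of change. Still open, from the compounds shown here alone, is whether a group carrying a basic amine or a carboxylic acid at this position would give a step beyond the scatter.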